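Fluoro in Place of Hydrogen: From Compound 2 to Compound 3

The compounds below may be only part of what the source reports. "The series", "measured", "known", "first", "only" and "open" are said of these compounds alone.

Compound 1 `O=C(Nc1nc2ccc(F)cc2s1)c1cn(-c2ccccc2)nc1-c1ccc(Cl)cc1`: 4970 nM
Compound 2 `COc1ccc(-c2nn(-c3ccccc3)cc2C(=O)Nc2nc3ccccc3s2)cc1`: 10500 nM

Of the compounds shown here, two have been measured in a functional assay on HT-29 cells (Homo sapiens) for cytotoxicity, read by MTT assay, with a stated time of 72 h; a higher number here means a weaker inhibitor, a lower number a stronger inhibitor. Compound 1 gives 4970 nM and compound 2 gives 10500 nM, the higher of the two numbers; the gap between them lies beyond the usual scatter, so compound 2 is the weaker of the pair. These two compounds differ in more than one place, so the gap cannot be tied to any single change.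

Compound 3 `COc1ccc(-c2nn(-c3ccccc3)cc2C(=O)Nc2nc3ccc(F)cc3s2)cc1` arises from compound 2 by one change: fluoro in place of hydrogen on an aromatic carbon. Going by the values given here, no measured pair shows this change on its own, so its effect here is not known. Compound 1 carries the same fluoro on the shared core alongside a different group on the other ring, and its value of 4970 nM is only a loose hint that the fluoro-bearing form can sit lower. Compound 3 is therefore expected to land close to compound 2, perhaps slightly lower. The expected step of a 1.5-fold lower number from compound 2 to compound 3 (0.18 log units; within the scatter) is a modest lowering, not clearly beyond the scatter. For compound 3 the estimated value is 7000 nM, with a range from 3000 nM to 16000 nM.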

Compound 3, half-maximal inhibitory concentration: 5560 nM
Compound 3: the middle estimate sits 1.3-fold (0.10 log units) above what was measured, and the stated range covers the measured number.
By their numbers in this assay, from the lowest: compounds 1, 3 and 2 (each within the scatter of the next, the first and the last beyond it).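

Going by these compounds alone, with this result, the change from 1,3-benzothiazol-2-yl to 6-fluoro-1,3-benzothiazol-2-yl can be read on its own for the first time: in this assay it gives a 1.9-fold lower number from compound 2 to compound 3 (0.28 log units; within the scatter), so at this position the fluoro produces no shift that can be told apart from the ordinary spread of repeated measurements. Compound 3 also provides a second comparison in which only one place differs, methoxy in place of chloro on an aromatic carbon, which gives a 1.1-fold higher number from compound 1 to compound 3 (0.05 log units; within the scatter), so with the fluoro present these two groups cannot be separated in this assay either. No outside measurement is available to explain either step.

The compounds shown carry only hydrogen or fluoro at this position, so it remains open whether an amine or a carboxylic acid there would move the number beyond the scatter. Also open, from the compounds shown here alone, are what a longer chain such as ethoxy would do in the place held by methoxy and chloro, and whether going from hydrogen to fluoro gives a similar step when chloro rather than methoxy is present.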